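A few compounds are considered here, and "the series" means these few. Any claim that something is new, unique, unknown or untested is made for them only; others in the source may bear on it.

The measured compounds and their values:

Compound 1 `CCc1ccccc1-c1n[nH]c(-c2cccc(OC)c2)n1` gives 0.04 mg/kg in a functional assay on the whole organism (Cricetulus griseus) with Cricetinae gen. sp. as the target; on this read-out lower numbers stand for an effect already at smaller amounts and higher numbers for an effect only at larger amounts of compound.
Compound 2 `CCCCc1ccccc1-c1n[nH]c(-c2cccc(OC)c2)n1` gives 12 mg/kg in this assay.
Compound 3 `Cc1cc(Cl)ccc1-c1n[nH]c(-c2ccccc2)n1` gives 0.14 mg/kg in this assay.

Among these three numbers compound 3 stands second highest. Its nearest neighbour is compound 1, which gives a lower number, and the gap between them lies beyond the scatter; compound 2 is furthest away with a higher number, again beyond the scatter.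

Compound 4 `COc1ccc(-c2n[nH]c(-c3ccccc3)n2)c(C)c1` has not yet been measured in this assay. It differs from compound 3 in one place: methoxy in place of chloro on an aromatic carbon.

Among the measured compounds shown here, the only step measured so far between two compounds differing in one place is a 300-fold higher number from compound 1 to compound 2 (2.48 log units; beyond the scatter). That step concerns a saturated chain grown from an aromatic carbon, not the exchange of one small group for another on the ring itself, so it does not bear on the change from compound 3 to compound 4. Nothing measured here tells how this assay responds to methoxy in place of chloro on this ring. In the absence of a bearing step, compound 4 is expected to give a number close to that of compound 3, with the step of no change at the digits printed from compound 3 to compound 4 (within the scatter) estimated to stay within the scatter. The estimate for compound 4 is 0.14 mg/kg, with a range from 0.03 mg/kg to 0.7 mg/kg.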

Compound 4, dose for half-maximal effect: > 10 mg/kg
Compound 4: a limit, no number (the forecaster's own chance of this, stated with the estimate: 5%); middle value at least 71-fold (1.85 log units) from the limit.
By their numbers in this assay, from the lowest: compound 1; then compound 3; then compound 2.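

The exchange of chloro for methoxy on this aromatic carbon, para to a large group and meta to a methyl group, brings an at least 71-fold higher number from compound 3 to compound 4 (1.85 log units; beyond the scatter) in this assay. Before this result, the only step between compounds differing in one place lay on a saturated chain, a 300-fold higher number from compound 1 to compound 2 (2.48 log units; beyond the scatter), and it left the ring substituent of compound 3 untested; this step shows that the read-out also responds strongly to a small exchange on the ring itself, where chloro with 1 heavy atom gives way to methoxy with 2 heavy atoms and 1 hydrogen-bond acceptor. Compound 4 gives > 10 mg/kg, which is a limit and not a number: the limit of > 10 mg/kg in this assay, at which 1 of the 4 values shown sits.

The compounds shown leave open whether the loss follows from removing chloro or from introducing methoxy, a question that hydrogen, fluoro or hydroxyl at this place could help to separate. They also leave open whether the same exchange would have a comparable effect on a compound with a second ring carrying methoxy, as in compound 1, or with a longer chain such as propyl at the other ring position.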